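The source may report more compounds than this note shows. Statements on the series, on what has been measured and on what is new or still open speak of the compounds shown alone.

Measured compounds in a functional assay on A549 cells (Homo sapiens) for cytotoxicity, read by MTT assay, with a stated time of 72 h; on this read-out lower numbers stand for stronger inhibition and higher numbers for weaker inhibition:
compound 1 `O=C(/C=C/c1cccc(Cl)c1Cl)Nc1cc2c(Nc3ccc(F)c(Cl)c3)ncnc2cc1O[C@H]1CCOC1`, 23200 nM
compound 2 `COc1cc(/C=C/C(=O)Nc2cc3c(Nc4ccc(F)c(Cl)c4)ncnc3cc2OC)cc(OC)c1`, "not active" (no number reported)
compound 3 `COc1cc2ncnc(Nc3ccc(F)c(Cl)c3)c2cc1NC(=O)/C=C/c1ccc(C#N)cc1`, "not active" (no number reported)

Compound 1 stands as the only entry in this series with a number; compound 2 and compound 3 are each recorded as inactive and give no value to compare against. Among the measured compounds shown here, no two measured compounds differ in one place, so the size of a single structural change cannot be read from the measured set, and the weight of any estimate rests on compound 1 alone.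

Compound 4 `COc1ccc(/C=C/C(=O)Nc2cc3c(Nc4ccc(F)c(Cl)c4)ncnc3cc2O[C@H]2CCOC2)c(OC)c1OC` is still to be measured in this assay. It differs from compound 1 by 2,3,4-trimethoxyphenyl in place of 2,3-dichlorophenyl on a double-bonded chain carbon bound to a double-bonded chain carbon. The shared core of compound 1, with its anilino substituent and its cyclic ether, is kept unchanged.

Nothing measured shows that a change on the double-bonded chain carbon adds potency: the two other variants at that position, compound 2 and compound 3, return no number. The step from compound 1 to compound 4 is therefore expected to be none beyond the scatter or toward weaker inhibition, with a real chance that this assay reports only a limit. Compound 4 is expected to give 40000 nM, within 12000 nM to 130000 nM. That estimate means an expected step of a 1.7-fold higher number from compound 1 to compound 4 (0.24 log units; within the scatter).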

Compound 4, half-maximal inhibitory concentration: 70 nM
Estimate against measurement, compound 4: 570-fold (2.76 log units) above; measured number outside the range, below it.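

In this assay, the step of a 330-fold lower number from compound 1 to compound 4 (2.52 log units; beyond the scatter) shows that the group on a double-bonded chain carbon bound to a double-bonded chain carbon can strongly shift this read-out while the shared core, its anilino substituent and its cyclic ether stay unchanged. Before this pair, the series held a single number and two entries recorded as not active, so no step could be read and the effect of this position could not be sized; compound 2 and compound 3 still give no readable step. The change from 2,3-dichlorophenyl to 2,3,4-trimethoxyphenyl removes chlorine and brings in oxygen and hydrogen-bond acceptors, but no measurement available here accounts for the size of the step.

Still open, from the compounds shown here alone, is whether the lower number needs all the methoxy groups of 2,3,4-trimethoxyphenyl, or whether a phenyl bearing a single methoxy group, or one bearing a dimethylamino group or a carboxylic acid, would give a similar result. Also open, going by these compounds, is whether the step holds when the cyclic ether is replaced, for example by a longer chain ending in an amine.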